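The source may hold more compounds than are shown below. What is called first, only, known or untested is meant among the compounds shown, and "the series" means these compounds.

Measured so far in an in vitro assay on 293-EBNA cells for binding affinity to corticotropin-releasing factor receptor 1 (Homo sapiens); on this read-out lower numbers stand for stronger inhibition and higher numbers for weaker inhibition: compound 1 `CCC(COC)N(C)c1nc(C)nc2c1nnn2-c1ccc(C(C)C)cc1Br` gives 11.2 nM; compound 2 `COCCCNc1nc(C)nc2c1nnn2-c1ccc(C(C)C)cc1Br` gives 291 nM; compound 3 `CCN(CC)c1nc(C)nc2c1ncn2-c1ccc(C(C)C)cc1Br` gives 12.4 nM.

Compound 3 stands second highest of these three numbers, within the scatter of compound 1 and far from compound 2. Compound 4 `CCCCN(CC)c1nc(C)nc2c1ncn2-c1ccc(C(C)C)cc1Br` differs from compound 3 by ethyl in place of hydrogen on a saturated chain carbon, two bonds along the chain from a nitrogen on an aromatic ring. Among the compounds with values here, the one counted step, a 26-fold higher number from compound 1 to compound 2 (1.41 log units; beyond the scatter), also alters the amine portion of this series and shows that a smaller group there cost much affinity; a larger group is not directly tested by it. Compound 1, carrying a larger branched amine, and compound 3 lie within the scatter of each other, so growing the chain seems tolerated. The expected step of a 1.2-fold lower number from compound 3 to compound 4 (0.09 log units; within the scatter) is therefore small, within the scatter. Compound 4 is estimated at 10 nM, ranging from 4 nM to 30 nM.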

Compound 4, inhibition constant: 4.3 nM
Compound 4: middle estimate off by 2.3-fold (0.37 log units), on the high side; the measured number falls inside the stated range.
By their numbers in this assay, from the lowest: compound 4; then compounds 1 and 3 (each within the scatter of the next); then compound 2.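

In this assay, the change from diethylamino to butyl(ethyl)amino gives a 2.9-fold lower number from compound 3 to compound 4 (0.46 log units; beyond the scatter), a modest step beyond the scatter. Within the data shown here, the earlier compounds showed only that a smaller amine group can cost much affinity, whereas this pair shows that extending one chain on the amine can strengthen inhibition. No supporting measurement here explains this gain. From the compounds shown here alone, whether a longer chain such as hexyl would strengthen inhibition further remains open. So does whether a chain ending in a hydroxyl group or a cyclopropyl ring would keep the gain.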